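The compounds below may be only part of what the source reports. "The series", "measured", "known", "first", "only" and "open" are said of these compounds alone.

Measured compounds in a functional assay on MDA-MB-231 cells (Homo sapiens) for antiproliferative activity, read by MTT assay, with a stated time of 48 h; on this read-out higher numbers stand for weaker inhibition and lower numbers for stronger inhibition:

compound 1 `C/C(=C\CC/C(C)=C/CC[C@@H]1[C@@]2(C)CCC(=O)C(C)(C)[C@H]2CC[C@@]1(C)O)CC/C=C(\C)C(=O)OCc1cn(-c2ccc(C(F)(F)F)cc2)nn1`, > 150000 nM
compound 2 `C/C(=C\CC/C(C)=C/CC[C@@H]1[C@@]2(C)CCC(=O)C(C)(C)[C@H]2CC[C@@]1(C)O)CC/C=C(\C)C(=O)OCc1cn(-c2ccccc2F)nn1`, > 150000 nM
compound 3 `C/C(=C\CC/C(C)=C/CC[C@@H]1[C@@]2(C)CCC(=O)C(C)(C)[C@H]2CC[C@@]1(C)O)CC/C=C(\C)C(=O)OCc1cn(-c2cccc(C(F)(F)F)c2)nn1`, > 150000 nM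

Each of these values is a limit of this assay, not a number. Compound 1 stands only at that limit, as do the two other measured compounds, so no order among the three can be read. The step to the unmeasured compound 4 `C/C(=C\CC/C(C)=C/CC[C@@H]1[C@@]2(C)CCC(=O)C(C)(C)[C@H]2CC[C@@]1(C)O)CC/C=C(\C)C(=O)OCc1cn(-c2cccc(O)c2)nn1` is 3-hydroxyphenyl in place of 4-(trifluoromethyl)phenyl on an aromatic nitrogen. The measured steps that touch the same position are a step that the two limits leave unreadable from compound 1 to compound 2 and a step that the two limits leave unreadable from compound 1 to compound 3; the step that the two limits leave unreadable from compound 2 to compound 3 is likewise not readable, because of the limit of > 150000 nM in this assay, at which 3 of the 3 values shown sit. Nothing in these data therefore sets a size or a direction for the step from compound 1 to compound 4 beyond the shared limit; the expectation is that compound 4 also stays at or near that limit, with a step that the limit leaves unreadable from compound 1 to compound 4 meaning no readable change. Compound 4 is estimated at 200000 nM, within 80000 nM to 500000 nM, most likely reported only as a limit.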

Compound 4, half-maximal inhibitory concentration: 139000 nM
The estimate for compound 4 lay 1.4-fold (0.16 log units) above the measured number; the range from low to high includes it.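

In this assay, among the compounds shown here, compound 4 gives 139000 nM, the first true number for any group on this aromatic nitrogen, with 3-hydroxyphenyl bringing 1 hydrogen-bond donor and 1 hydrogen-bond acceptor in place of 4-(trifluoromethyl)phenyl. The comparisons show an at least 1.0-fold lower number from compound 1 to compound 4 (0.03 log units; that floor lies within the scatter), an at least 1.0-fold lower number from compound 3 to compound 4 (0.03 log units; that floor lies within the scatter) and an at least 1.0-fold lower number from compound 2 to compound 4 (0.03 log units; that floor lies within the scatter), so these floors do not establish a change in either potency or order. The true size of each step remains unknown because the other compounds give no number to compare against: the limit of > 150000 nM in this assay, at which 3 of the 4 values shown sit.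

From the compounds shown here alone, it remains open whether an amine or a carboxylic acid in place of the hydroxy on the aromatic carbon would give a number clearly beyond the scatter from compound 4. The same holds for a longer chain in place of the whole 3-hydroxyphenyl group.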